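The source may hold more compounds than are shown below. What is called first, only, known or untested is meant among the compounds shown, and "the series" means these compounds.

Measured compounds in this set:

compound 1 `Cc1cc(N(C)C(N)=O)cc(C)c1CCS(=O)(=O)N1CCC2(CC1)N=C([C@H]1CC[C@H](C)CC1)NC2=O` — 250 ug/mL
compound 2 `CC(=O)Nc1ccc(CCS(=O)(=O)N2CCC3(CC2)N=C(C2CCCCC2)NC3=O)c(C)c1` — 400 ug/mL
compound 3 `Cc1ccccc1CCS(=O)(=O)N1CCC2(CC1)N=C(C1CCCCC1)NC2=O` — 15 ug/mL

In a physicochemical assay for solubility, read by HPLC, in simulated intestinal fluid, tested at 1 mM (on this read-out higher numbers stand for higher solubility and lower numbers for lower solubility), compound 1 gives 250 ug/mL, the second highest of the three numbers; compound 2 gives 400 ug/mL, which lies within the scatter of compound 1, while compound 3 gives 15 ug/mL, well below both. For the measured compounds named here, the only step between measured compounds that differ in one place is a 27-fold lower number from compound 2 to compound 3 (1.43 log units; beyond the scatter), an aromatic substituent change that does not bear directly on the ring change considered here.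

Compound 4 `Cc1cc(N(C)C(N)=O)cc(C)c1CCS(=O)(=O)N1CCC2(CC1)N=C(C1CCCCC1)NC2=O` differs from compound 1 by hydrogen in place of methyl on a saturated ring carbon. Going by the values given here, no measured pair isolates this change. Compound 2 carries the same cyclohexyl group as compound 4 and sits within the scatter of compound 1, so a small or no change beyond the scatter is expected from compound 1 to compound 4, leaning slightly upward, giving an estimated step of a 1.4-fold higher number from compound 1 to compound 4 (0.15 log units; within the scatter). Compound 4 is therefore expected to give about 350 ug/mL, in the range 170 ug/mL to 700 ug/mL.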

Compound 4, solubility: 450 ug/mL
Beside the measured number, compound 4's estimate is 1.3-fold (0.11 log units) below it; low and high end bracket the measured number.
By their numbers in this assay, from the lowest: compound 3; then compounds 1, 2 and 4 (each within the scatter of the next).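

In this assay, for the compounds shown here, the pair compound 1 and compound 4 gives the first direct reading of 4-methylcyclohexyl to cyclohexyl, with a 1.8-fold higher number from compound 1 to compound 4 (0.26 log units; within the scatter) for this change. On this saturated ring carbon, three ring bonds from the ring atom that bears a large group, methyl and hydrogen are therefore not told apart by this read-out, at least with the aromatic substitution these two compounds share. No supporting measurement is available to explain this reading.

The compounds shown cover only methyl and hydrogen at this carbon, so the reading for an amine, a carboxylic acid or a longer chain there remains open. Also open, going by these compounds, is whether 4-methylcyclohexyl to cyclohexyl reads the same with a different aromatic substituent, such as the acetamido group of compound 2.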